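A few compounds are considered here, and "the series" means these few. Any claim that something is new, unique, unknown or untested is made for them only; others in the source may bear on it.

In a functional assay on KB cells (Homo sapiens) for antiproliferative activity, read by MTT assay, with a stated time of 48 h (a lower number here means a stronger inhibitor, a higher number a weaker inhibitor), compound 3 `CN(C)CCCn1nc(C2=C(c3cn(C)c4ccccc34)C(=O)N(c3ccccc3)C2=O)c2cccnc21` gives 14100 nM, the highest of the three measured numbers, which makes it the weakest of the three. Compound 1 `Cn1cc(C2=C(c3nn(CCCN4CCCCC4)c4ncccc34)C(=O)N(c3ccccc3)C2=O)c2ccccc21` gives 5600 nM and compound 2 `Cn1cc(C2=C(c3nn(CCCn4ccnc4)c4ncccc34)C(=O)N(c3ccccc3)C2=O)c2ccccc21` gives 6800 nM. These two cannot be told apart, as a 1.2-fold higher number from compound 1 to compound 2 (0.08 log units; within the scatter) shows.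

Compound 4 `Cn1cc(C2=C(c3nn(CCCCn4ccnc4)c4ncccc34)C(=O)N(c3ccccc3)C2=O)c2ccccc21` has not yet been measured. Its difference from compound 3 is (1H-imidazol-1-yl)methyl in place of dimethylamino on a saturated chain carbon, three bonds along the chain from an aromatic nitrogen. In words, (1H-imidazol-1-yl)methyl stands in place of dimethylamino on a saturated chain carbon, three bonds along the chain from an aromatic nitrogen, so 3-(dimethylamino)propyl becomes 4-(1H-imidazol-1-yl)butyl.

The closest evidence is the measured exchange of end groups on the shared core. Going to dimethylamino from 1H-imidazol-1-yl gave a 2.1-fold higher number from compound 2 to compound 3 (0.32 log units; beyond the scatter), and going to it from piperidin-1-yl gave a 2.5-fold higher number from compound 1 to compound 3 (0.40 log units; beyond the scatter). Both steps are modest. The new change leaves dimethylamino for an imidazole end, so it runs opposite to the first of these, and a modest fall in the number is expected. Among the compounds with values here, no measured pair shows what a longer chain does, so the range has to stay wide.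

The estimated change is a 2.0-fold lower number from compound 3 to compound 4 (0.30 log units; within the scatter). For compound 4 the expected value is 7000 nM, with an estimated range from 3000 nM to 15000 nM.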

Compound 4, half-maximal inhibitory concentration: 47300 nM
The estimate for compound 4 lay 6.8-fold (0.83 log units) below the measured number; the whole stated range lies below it.
By their numbers in this assay, from the lowest: compounds 1 and 2 (each within the scatter of the next); then compound 3; then compound 4.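

In this assay, within the data shown here, the step that keeps the imidazole end and changes only the chain, from 3-(1H-imidazol-1-yl)propyl to 4-(1H-imidazol-1-yl)butyl, is a 7.0-fold higher number from compound 2 to compound 4 (0.84 log units; beyond the scatter) and shows that chain length at this position matters, something the earlier compounds could not show, since all three carry a propyl chain. This step is larger than any exchange of end groups on the propyl chain, and the other two steps run the same way, with a 3.4-fold higher number from compound 3 to compound 4 (0.53 log units; beyond the scatter) and an 8.4-fold higher number from compound 1 to compound 4 (0.93 log units; beyond the scatter) making compound 4 the weakest of the four. The data offer nothing that explains why the longer chain gives a higher number.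

As far as these compounds go, whether lengthening the chain has the same result with other end groups remains open, as the outcome for a 4-(dimethylamino)butyl chain or a butyl chain ending in piperidin-1-yl is unknown here. Also open, from the compounds shown here alone, is whether a shorter chain, such as 2-(1H-imidazol-1-yl)ethyl, would give a lower number than the propyl compounds or a higher one.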